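A few compounds are considered here, and "the series" means these few. Any claim that something is new, unique, unknown or untested is made for them only; others in the source may bear on it.

Compound 1 `COC(=O)c1cc(-c2cccc(NC(=O)c3ccc(/C=C/C(=O)c4cccc(Cl)c4)cc3)c2)on1`: in an ADME assay on Vero cells (Chlorocebus sabaeus) for cytotoxicity, read by MTT assay, with a stated time of 72 h (a higher number here means that more compound is tolerated, a lower number that less compound is tolerated), compound 1 gives only a limit, > 2.5 ug/mL.
Compound 2 `COC(=O)c1cc(-c2cccc(NC(=O)c3ccc(/C=C/C(=O)c4cccc(C(F)(F)F)c4)cc3)c2)on1`: in this assay compound 2 gives only a limit, > 20 ug/mL.
Compound 3 `COC(=O)c1cc(-c2cccc(NC(=O)c3ccc(/C=C/C(=O)c4ccccc4C)cc3)c2)on1`: in this assay compound 3 gives only a limit, > 25 ug/mL.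

Compound 3 thus stands on a limit rather than a number, and the two further values shown are likewise limits, as the evidence records at the limit of > 2.5 ug/mL in this assay, at which 1 of the 3 values shown sits, the limit of > 20 ug/mL in this assay, at which 1 of the 3 values shown sits, and (the limit of > 25 ug/mL in this assay, at which 1 of the 3 values shown sits). Going by the values given here, no compound can be placed above or below another on these figures.

The piece follows the move to compound 4 `COC(=O)c1cc(-c2cccc(NC(=O)c3ccc(/C=C/C(=O)c4cc(OC)c(OC)c(OC)c4)cc3)c2)on1`, which differs from compound 3 in one place: 3,4,5-trimethoxyphenyl in place of 2-methylphenyl on a carbonyl carbon.

Among the compounds with values here, three measured steps bear on this move, all ending at or passing through compound 3 or its neighbours: a step that the two limits leave unreadable from compound 1 to compound 3, a step that the two limits leave unreadable from compound 2 to compound 3 and a step that the two limits leave unreadable from compound 1 to compound 2. Each is left unreadable by the two limits involved, so none gives a size or a direction from which to reason. The author therefore expects no step beyond the scatter and anticipates that compound 4 will most likely again return only a limit in this assay. For compound 4 the estimate is 30 ug/mL, within a range of 10 ug/mL to 80 ug/mL. This estimate corresponds to an expected step that the limit leaves unreadable from compound 3 to compound 4.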

Compound 4, half-maximal cytotoxic concentration: > 50 ug/mL
Compound 4 ended at the assay's limit (the forecaster's own chance of this, stated with the estimate: 70%); middle value at least 1.6-fold (0.22 log units) from the limit.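

In this assay compound 4 gives only a limit, > 50 ug/mL. Going by these compounds alone, compound 1, compound 2 and compound 3 also give only limits, so no step to compound 4 can be read, in either size or direction. The compounds shown leave open what concentration of any of the four is actually tolerated, and whether these aryl changes alter it.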